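The source may report more compounds than this note shows. Statements on the series, on what has been measured and on what is new or still open speak of the compounds shown alone.

Measured compounds:
- compound 1 `Cc1nc(NCCNC(=O)C2CC2)nc2ccc(NC(=O)/C=C/c3ccc(OC(F)(F)F)cc3)cc12`: 23 nM
- compound 2 `COCC(=O)NC1CCN(c2nc(C)c3cc(NC(=O)/C=C/c4ccc(OC(F)(F)F)cc4)ccc3n2)CC1`: 14 nM
- compound 3 `Cc1nc(N2CCC(N3CCNC3=O)CC2)nc2ccc(NC(=O)/C=C/c3ccc(OC(F)(F)F)cc3)cc12`: 31 nM

In a functional assay on CHO-K1 cells for antagonist activity at melanin-concentrating hormone receptor 1 (Homo sapiens), read by inositol phosphate accumulation, with stated times of 10 min and 45 min (a lower number here means a stronger inhibitor, a higher number a weaker inhibitor), compound 3 gives the highest of the three numbers; its gap to compound 1 is within the scatter, and only its gap to compound 2 is beyond it, as seen in a 2.2-fold higher number from compound 2 to compound 3 (0.35 log units; beyond the scatter). Compound 4 `Cc1nc(NCCNS(C)(=O)=O)nc2ccc(NC(=O)/C=C/c3ccc(OC(F)(F)F)cc3)cc12` is not yet measured. It differs from compound 3 in one place: (2-(methanesulfonamido)ethyl)amino in place of 4-(2-oxoimidazolidin-1-yl)piperidin-1-yl on an aromatic carbon. The substituent on that carbon, which lies between two ring nitrogen atoms of the shared core, thus changes from a ring-bearing piperidine group to an open chain carrying a sulfonamide.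

The closest measured guide is the step in the opposite sense, from an open chain to this piperidine group, a 1.3-fold higher number from compound 1 to compound 3 (0.13 log units; within the scatter), which stayed within the scatter; the step of a 1.6-fold lower number from compound 1 to compound 2 (0.22 log units; within the scatter) was equally small. Within the data shown here, the one step beyond the scatter, a 2.2-fold higher number from compound 2 to compound 3 (0.35 log units; beyond the scatter), was modest. All three variations of this group therefore moved this assay little, and the estimate for compound 4 is a similarly small step, a 1.2-fold lower number from compound 3 to compound 4 (0.09 log units; within the scatter), within the scatter. Compound 4 is expected to give about 25 nM, between 10 nM and 70 nM.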

Compound 4, half-maximal inhibitory concentration: 142 nM
For compound 4 the middle estimate is 5.7-fold (0.75 log units) below the measured one, and the stated range ends below it.
By their numbers in this assay, from the lowest: compounds 2, 1 and 3 (each within the scatter of the next, the first and the last beyond it); then compound 4.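

In this assay, keeping the open chain and changing only its end group, with methylsulfonyl in place of cyclopropylcarbonyl on the amine nitrogen, gives a 6.2-fold higher number from compound 1 to compound 4 (0.79 log units; beyond the scatter), so the end of this chain matters even though the earlier changes on this aromatic carbon moved the number little. The steps from the two piperidine compounds, a 4.6-fold higher number from compound 3 to compound 4 (0.66 log units; beyond the scatter) and a 10-fold higher number from compound 2 to compound 4 (1.01 log units; beyond the scatter), are also beyond the scatter, and the latter is large, so this position is less forgiving than the first three compounds suggested. Nothing measured here explains the weaker result.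

Going by these compounds, it remains open whether a methanesulfonamido group on the piperidine ring would weaken activity in the same way. The effect of a phenylsulfonyl group or a plain amine at the end of the chain is also unknown.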